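Will compound 4 keep the stability of compound 3?

This account rests on a few compounds, and the source may have more. Where it says the series, first, only, none or still open, it means among the compounds named here.

In an ADME assay on microsomes from liver (Rattus norvegicus) for metabolic stability, using NADPH, with a stated time of 10 min (on this read-out higher numbers stand for a more stable compound and lower numbers for a less stable compound), compound 1 (`NC/C=C\CN(C[C@H]1Cc2ncccc2CN1)[C@H]1CCCc2cccnc21`) gives 11% and compound 2 (`CCN(CC)CCCCN(C[C@H]1Cc2ncccc2CN1)[C@H]1CCCc2cccnc21`) gives 6% while compound 3 (`CN(CCCCN(C[C@H]1Cc2ncccc2CN1)[C@H]1CCCc2cccnc21)C1CCOCC1`) reaches 64% as the highest of the three. Compound 4 (`c1cnc2c(c1)CN[C@@H](CN(CCCC1CCNCC1)[C@H]1CCCc3cccnc31)C2`) carries piperidin-4-yl in place of (methyl(oxan-4-yl)amino)methyl on a saturated chain carbon, three bonds along the chain from an amine nitrogen. Two large steps bear on this, a number 58 percentage points higher from compound 2 to compound 3 (beyond the scatter) and a number 53 percentage points higher from compound 1 to compound 3 (beyond the scatter) while a number 5 percentage points lower from compound 1 to compound 2 (within the scatter) stays within the scatter. Compound 4 gives up the methyl(oxan-4-yl)amino group of compound 3, so part of the rise in a number 58 percentage points higher from compound 2 to compound 3 (beyond the scatter) may be lost. Going by the values given here, no measured compound carries piperidin-4-yl. The expected step in this assay is a number 26 percentage points lower from compound 3 to compound 4 (beyond the scatter) as a rough estimate. Compound 4 is therefore estimated at 38% (expected range 10% to 72%).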

Compound 4, percent of the compound remaining: 40%
Compound 4: middle estimate off by 2 percentage points, on the low side; the range from low to high includes it.
By their numbers in this assay, from the lowest: compounds 2 and 1 (each within the scatter of the next); then compound 4; then compound 3.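

In this assay, piperidin-4-yl does not hold the level set by (methyl(oxan-4-yl)amino)methyl (a number 24 percentage points lower from compound 3 to compound 4 (beyond the scatter)), yet compound 4 stays clear of the two low compounds (a number 34 percentage points higher from compound 2 to compound 4 (beyond the scatter); a number 29 percentage points higher from compound 1 to compound 4 (beyond the scatter)). A high number at this place therefore does not require the methyl(oxan-4-yl)amino group, although the piperidin-4-yl replacement reaches less far. As far as these compounds go, whether a methyl group on the piperidine nitrogen or a longer chain to the piperidine ring would close the remaining gap stays open. No measurement at hand gives a reason for that gap.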